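Swapping the aryl group of a weak cinnamamide agonist

A few compounds are considered here, and "the series" means these few. Any claim that something is new, unique, unknown or untested is made for them only; others in the source may bear on it.

Measured compounds:
compound 1, `CCCc1cc(OC)c2cc(NC(=O)/C=C/c3ccc(C(F)(F)F)cc3)ccc2n1`: 360 nM
compound 2, `CCCc1cc(N)c2cc(NC(=O)/C=C/c3ccc(Cl)cc3Cl)ccc2n1`: 904 nM
compound 3, `CC(C)c1cc(N)c2cc(NC(=O)/C=C/c3ccc(C(F)(F)F)cc3)ccc2n1`: 160 nM

In a functional assay on HEK293 cells for activation of melanin-concentrating hormone receptor 1 (Homo sapiens), read by inositol phosphate accumulation (on this read-out higher numbers stand for an effect only at larger amounts of compound and lower numbers for an effect already at smaller amounts), compound 2 gives 904 nM, the highest number of the three. Compound 1 gives 360 nM and compound 3 gives 160 nM, both beyond the scatter from compound 2, though each differs from it in more than one place. Compound 4, `CCCc1cc(N)c2cc(NC(=O)/C=C/c3ccc(SC)cc3)ccc2n1`, has not yet been measured. Its change from compound 2 is 4-(methylsulfanyl)phenyl in place of 2,4-dichlorophenyl on a double-bonded chain carbon bound to a double-bonded chain carbon. With both comparison compounds carrying a trifluoromethylphenyl group and showing lower numbers, compound 4 is expected to move to a lower number, in a step of a 2.3-fold lower number from compound 2 to compound 4 (0.35 log units; beyond the scatter) that probably exceeds the scatter but stays moderate. Compound 4 is estimated at 400 nM, within 130 nM to 1200 nM.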

Compound 4, half-maximal effective concentration: 71 nM
For compound 4 the middle estimate is 5.6-fold (0.75 log units) above the measured one; measured number below the stated range.
By their numbers in this assay, from the lowest: compound 4; then compound 3; then compound 1; then compound 2.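

In this assay, among these compounds, the aryl group on the double-bonded chain carbon now has a step of its own, which the earlier compounds, differing in more than one place, could not give. With the rest of the molecule unchanged, 4-(methylsulfanyl)phenyl in place of 2,4-dichlorophenyl brings a 13-fold lower number from compound 2 to compound 4 (1.10 log units; beyond the scatter) and so marks this position as one where a single swap has a large effect. Nothing available here accounts for the step.

Still open, from the compounds shown here alone, is how 4-methoxyphenyl or 4-(methylsulfonyl)phenyl would read at this place on the same core. Also open, going by these compounds, is where 4-(trifluoromethyl)phenyl, carried by compound 1 and compound 3 alongside other changes, would stand on that core.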